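Acetyl to dimethylamino on the aryl of compound 1

The compounds below may be only part of what the source reports. "The series", "measured", "known", "first", "only" and "open" are said of these compounds alone.

Values in a functional assay on SF-295 cells (Homo sapiens) for inhibition, read by sulforhodamine B assay, with a stated time of 48 h; a higher number here means that more compound is tolerated, a lower number that less compound is tolerated:
Compound 1 `COc1cc(C)cc(-c2c(-c3ccnc(-c4ccc(C(C)=O)cc4)c3)cnn2CC#N)c1`: > 100000 nM, a limit of the assay.
Compound 2 `Cc1cc(O)cc(-c2nn(CC#N)cc2-c2ccnc(-c3ccc(Oc4ccccc4)cc3)c2)c1`: 75200 nM.
Compound 3 `Cc1cc(O)cc(-c2nn(CC#N)cc2-c2ccnc(-c3ccc(N(C)C)cc3)c2)c1`: 84100 nM.

Compound 1 stands at the top of the numbers shown, since its value is a limit only the limit of > 100000 nM in this assay, at which 1 of the 3 values shown sits, and no number is known for it. Compound 2 and compound 3 give numbers that are close to each other, with a 1.1-fold higher number from compound 2 to compound 3 (0.05 log units; within the scatter).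

The step to compound 4 `COc1cc(C)cc(-c2c(-c3ccnc(-c4ccc(N(C)C)cc4)c3)cnn2CC#N)c1` is dimethylamino in place of acetyl on an aromatic carbon. Among the compounds with values here, the only measured step that bears on it is a 1.1-fold higher number from compound 2 to compound 3 (0.05 log units; within the scatter): it also brings in dimethylamino on an aromatic carbon of the pendant aryl, but in place of phenoxy rather than acetyl, and on a core bearing a hydroxy rather than a methoxy group, so it is not a direct match. That step lay within the scatter. Within the data shown here, no measured pair exchanges acetyl for anything.

Compound 3 with its dimethylamino group gives 84100 nM, a number rather than a limit, so for compound 4 the expected step of an at least 1.1-fold lower number from compound 1 to compound 4 (0.04 log units; that floor lies within the scatter) is small. Compound 4 is expected at 90000 nM, with a range of 40000 nM to 200000 nM, and a limit is again a fair possibility.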

Compound 4, concentration lethal to 50% of the cells: > 100000 nM
Compound 4: a limit, no number; the forecaster's own chance of this, stated with the estimate: 45%; at least 1.1-fold (0.04 log units) between middle value and limit.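

Compound 1 and compound 4 each give only a limit in this assay, so the step from acetyl to dimethylamino on the shared core cannot be read: the limit of > 100000 nM in this assay, at which 2 of the 4 values shown sit.

The compounds shown leave open how far apart compound 1 and compound 4 lie, and whether 4-acetylphenyl and 4-(dimethylamino)phenyl differ at all in this read-out.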